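A Further Methoxy on Compound 3

The source may hold more compounds than are shown below. What is called first, only, known or untested is meant among the compounds shown, and "the series" means these compounds.

In a functional assay on U-87MG ATCC cells for cytotoxicity against U-87 MG (Homo sapiens), read by colorimetric assay and MTT assay (on this read-out higher numbers stand for weaker inhibition and lower numbers for stronger inhibition), compound 1 `COc1cccc2cc(-c3ccccc3)c(O)nc12` gives 10000 nM, compound 2 `COc1cc(OC)c2cc(-c3ccccc3)c(O)nc2c1` gives 10000 nM and compound 3 `COc1ccc(-c2cc3cccc(OC)c3nc2O)cc1` gives 10000 nM, so compound 3 stands level with both. Compound 4 `COc1ccc(-c2cc3c(OC)ccc(OC)c3nc2O)cc1` differs from compound 3 by one change, methoxy in place of hydrogen on an aromatic carbon, para to a methoxy group. Within the data shown here, only one measured step is of the same kind, and it is no change at the digits printed from compound 1 to compound 3 (within the scatter). That single step is a thin guide, but it gives no reason to expect a shift beyond the scatter in this assay. The expected step is no change at the digits printed from compound 3 to compound 4 (within the scatter). For compound 4 the estimated value is 10000 nM, with an expected range from 5000 nM to 20000 nM.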

Compound 4, half-maximal inhibitory concentration: 10000 nM
Estimate against measurement, compound 4: no gap at the digits printed; the measured number falls inside the stated range.
By their numbers in this assay, from the lowest: compounds 1, 2, 3 and 4 (each within the scatter of the next).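

In this assay, methoxy in place of hydrogen on an aromatic carbon of the fused system of two rings, para to a methoxy group, gives no change at the digits printed from compound 3 to compound 4 (within the scatter). Among these compounds, the one earlier step of this kind, no change at the digits printed from compound 1 to compound 3 (within the scatter), lay at a different place, so this change has now left the value unmoved at two positions. No evidence is available to explain this flat result.

As far as these compounds go, whether an amine or a carboxylic acid at this same position would shift the value remains open. So does the effect of a longer chain there in place of methoxy.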